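Moving from a Dimethylphenyl Amide to a Chloromethoxyphenyl Amide

The source may hold more compounds than are shown below. What is called first, only, known or untested is meant among the compounds shown, and "the series" means these compounds.

Compound 1 `Cc1cc(C)cc(NC(=O)COc2cc(C)nc3ccc(C(F)(F)F)cc23)c1` gives > 100000 nM in a toxicity assay on HepG2 cells (Homo sapiens) for inhibition, read by CellTiter-Glo, with a stated time of 48 h (a higher number here means a weaker inhibitor, a lower number a stronger inhibitor), a limit of the assay.
Compound 2 `COc1ccc2nc(C)cc(OCc3ccc4ccccc4n3)c2c1` gives 31600 nM in this assay.
Compound 3 `COc1ccc2nc(C)cc(OCC(=O)Nc3c(C)cccc3C)c2c1` gives > 100000 nM in this assay, again a limit of the assay.

Compound 3 therefore stands at the edge of what this assay can report: its value is a limit, not a number, and it shares that position with compound 1, as the limit of > 100000 nM in this assay, at which 2 of the 3 values shown sit, shows. Only compound 2 returns a plain number in this assay.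

Compound 4 `COc1ccc2nc(C)cc(OCC(=O)Nc3ccc(Cl)c(OC)c3)c2c1` has not yet been tested. Against compound 3 it carries 4-chloro-3-methoxyphenyl in place of 2,6-dimethylphenyl on an amide-type nitrogen. No measured pair with this change exists among the compounds shown, so the expected step rests on the position of compound 3 alone, at a limit, and on compound 1 sitting at the same limit with a different amide substituent.

Compound 4 is expected to give 100000 nM in this assay. Its range is expected to run from 40000 nM to 300000 nM. The step expected is a number no higher from compound 3 to compound 4 (the limit leaves the size open), that is, none beyond the scatter, with a high chance that the assay once more reports only a limit.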

Compound 4, half-maximal inhibitory concentration: > 100000 nM
Compound 4 gave a limit, no number; the forecaster's own chance of this, stated with the estimate: 75%; the middle value sits exactly at the limit.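

Compound 3 and compound 4 both return a limit of the assay rather than a number, so no step can be read between them: the limit of > 100000 nM in this assay, at which 3 of the 4 values shown sit. The compounds shown leave open whether 4-chloro-3-methoxyphenyl and 2,6-dimethylphenyl differ at all in this assay.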